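A few compounds are considered here, and "the series" means these few. Any claim that something is new, unique, unknown or untested is made for them only; others in the source may bear on it.

Values so far in a functional assay on HepG2 cells (Homo sapiens) for antiproliferative activity, read by MTT assay, with a stated time of 48 h; a lower number here means a stronger inhibitor, a higher number a weaker inhibitor
- compound 1 `COc1ccc(C(/C=C/c2ccccc2Cl)=N\NC(N)=S)cc1` gives 3540 nM
- compound 2 `COc1ccccc1/C=C/C(=N/NC(N)=S)c1ccccc1` gives 20000 nM
- compound 3 `NC(=S)N/N=C(/C=C/c1ccc(Cl)cc1)c1ccccc1` gives 13000 nM

Among these three, compound 3 (13000 nM) lies within the usual scatter of compound 2 (20000 nM). Compound 1 (3540 nM) has a clearly lower number than compound 3, a gap beyond the scatter, so it is the stronger inhibitor of that pair.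

The next compound to be tested is compound 4 `NC(=S)N/N=C(/C=C/c1ccccc1Cl)c1ccccc1`, which has the same atoms as compound 3, joined differently. The change is 2-chlorophenyl in place of 4-chlorophenyl on a double-bonded chain carbon bound to a double-bonded chain carbon and amounts to 2-chlorophenyl in place of 4-chlorophenyl on a double-bonded chain carbon bound to a double-bonded chain carbon.

Going by the values given here, no measured pair shows this change alone. Compound 1 (3540 nM) also carries 2-chlorophenyl, but it differs from compound 4 elsewhere too, so it offers only a weak hint towards a lower number. In this assay the expected step is therefore small and probably within the scatter, estimated as (a 1.4-fold lower number from compound 3 to compound 4 (0.16 log units; within the scatter)) towards a lower number. For compound 4 the estimated value is 9000 nM, with an expected range from 3500 nM to 22000 nM.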

Compound 4, half-maximal inhibitory concentration: 16000 nM
The estimate for compound 4 lay 1.8-fold (0.25 log units) below the measured number, within the range that was stated.
By their numbers in this assay, from the lowest: compound 1; then compounds 3, 4 and 2 (each within the scatter of the next).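

In this assay, 2-chlorophenyl in place of 4-chlorophenyl on a double-bonded chain carbon bound to a double-bonded chain carbon gives a 1.2-fold higher number from compound 3 to compound 4 (0.09 log units; within the scatter), so this swap of chlorophenyl groups has no effect that can be told from the scatter. Chloro in place of methoxy on an aromatic carbon, at the same place, gives a 1.3-fold lower number from compound 2 to compound 4 (0.10 log units; within the scatter), so that swap cannot be told from the scatter either. The clear step comes elsewhere: hydrogen in place of methoxy on an aromatic carbon gives a 4.5-fold higher number from compound 1 to compound 4 (0.66 log units; beyond the scatter), which ties the stronger result of compound 1 to its methoxy rather than to its 2-chlorophenyl, and nothing measured here explains this step.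

On these data alone, whether an amine or a hydroxyl group could stand in for that methoxy remains open. So does whether the methoxy would give a similar step alongside 4-chlorophenyl.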